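Replacing an amino ester chain with methoxy

The source may report more compounds than this note shows. Statements on the series, on what has been measured and on what is new or still open speak of the compounds shown alone.

In an ADME assay on NIH3T3 cells (Mus musculus) for cytotoxicity (a lower number here means that less compound is tolerated, a higher number that more compound is tolerated), compound 1 (`CN1CCN(CC#Cc2cc3ncnc(Nc4ccc(OCc5cccc(F)c5)c(Cl)c4)c3s2)CC1`) gives 4.8 uM as a measured number. Compound 2 (`CN(C)CC#Cc1cc2ncnc(Nc3ccc(OCc4cccc(F)c4)c(Cl)c3)c2s1`) gives > 50 uM and this is a limit, not a number. Compound 3 (`CCOC(=O)CN(C)CC#Cc1cc2c(Nc3ccc(OCc4cccc(F)c4)c(Cl)c3)ncnc2s1`) gives > 50 uM and this is also a limit. Compound 3 therefore has no exact number (the limit of > 50 uM in this assay, at which 2 of the 3 values shown sit).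

Compound 4 (`COCC#Cc1cc2c(Nc3ccc(OCc4cccc(F)c4)c(Cl)c3)ncnc2s1`) is still unmeasured. It carries methoxy in place of ((ethoxycarbonyl)methyl)(methyl)amino on a saturated chain carbon bound to a triple-bonded carbon.

Among the compounds with values here, the only measured step at this place is an at least 10-fold higher number from compound 1 to compound 2 (1.01 log units; beyond the scatter) and it is large, with dimethylamino in place of 4-methylpiperazin-1-yl. That step shows that a change here can matter, but it involves different groups and gives only indirect guidance. In this assay the estimated step is a number no higher from compound 3 to compound 4 (the limit leaves the size open) and no change beyond the scatter is expected in either direction. The estimate for compound 4 is 50 uM with an expected range of 15 uM to 100 uM and a reading that is only a limit would be no surprise.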

Compound 4, half-maximal toxic concentration: 1.7 uM
Estimate against measurement, compound 4: 29-fold (1.47 log units) above; measured number below the stated range.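

Swapping the amino ester chain for methoxy is far from neutral at this position: in this assay there is an at least 29-fold lower number from compound 3 to compound 4 (1.46 log units; beyond the scatter), so a change on this saturated chain carbon can also push the number sharply down, whereas the earlier step here ran upward. Compound 3 stands at a limit, so this step has no exact size: the limit of > 50 uM in this assay, at which 2 of the 4 values shown sit.

An amine here does not by itself give a high number, since compound 1, with 4-methylpiperazin-1-yl, gives 4.8 uM.

Compound 4 loses the amine nitrogen and the ester together, so the compounds shown cannot separate what each contributes. As far as these compounds go, whether a hydroxyl, a carboxylic acid or a longer ether chain in this place would give a number nearer that of compound 3 or compound 4 remains open.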